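The source may report more compounds than this note shows. Statements on the series, on what has been measured and on what is new or still open speak of the compounds shown alone.

Compound 1, whose structure is `COc1ccccc1/C=c1/[nH]c(=O)/c(=C\c2cccc(Cl)c2Cl)[nH]c1=O`, carries a free ring nitrogen on its shared core. In a functional assay on A549 cells (Homo sapiens) for cytotoxicity, read by CCK-8 assay, with a stated time of 72 h (a lower number here means a stronger inhibitor, a higher number a weaker inhibitor), compound 1 gave "not active" (no number reported), so no single number is available for it. Compound 2, with structure `C=CCn1c(=O)/c(=C\c2cccc(Cl)c2Cl)[nH]c(=O)/c1=C\c1ccccc1OC`, differs in having an allyl group on that ring nitrogen, and in this assay compound 2 gives 2300 nM. Among the results available, compound 2 therefore holds the only measured number, while compound 1 stands apart as the one entry without a figure.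

Compound 3, whose structure is `C=CCn1c(=O)/c(=C\c2ccc(F)c(Br)c2)[nH]c(=O)/c1=C\c1ccccc1OC`, keeps the allyl group and the methoxyphenyl arm of compound 2 but changes the second aromatic arm: 3-bromo-4-fluorophenyl in place of 2,3-dichlorophenyl on a double-bonded chain carbon bound to an aromatic carbon. For the measured compounds named here, no measured pair in this set shows what such a swap of halogens on that ring does, so the direction of the step is uncertain.

Because compound 2 gives 2300 nM as the only anchor, the step of a 1.5-fold higher number from compound 2 to compound 3 (0.18 log units; within the scatter) is expected to stay within the usual scatter or to show at most a mild loss. Compound 3 is therefore estimated at 3500 nM, with a plausible range from 1000 nM to 12000 nM.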

Compound 3, half-maximal inhibitory concentration: "not active" (no number reported)
No number was reported for compound 3; the estimate stays without a comparison.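

In this assay compound 3 gives "not active" (no number reported), so no step can be read against compound 2 at 2300 nM. The compounds shown leave open how far the 3-bromo-4-fluorophenyl arm and the 2,3-dichlorophenyl arm differ in effect on these cells. Nothing measured here bears on this result.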